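Replacing a small ring with an aromatic one at the imidazole chain

The source may report more compounds than this note shows. Statements on the series, on what has been measured and on what is new or still open speak of the compounds shown alone.

Of the compounds shown here, three sharing one core have been tested in an in vitro functional assay on cells for agonist activity at Bombesin receptor subtype-3 (Mus musculus), read by luminescence and calcium flux; a higher number here means that more compound is needed for the effect, a lower number that less compound is needed. Compound 1 `O=C(O)c1ccccc1-c1ccc(CCc2ncc(CC3CCCCC3)[nH]2)cc1` gives 7.3 nM. Compound 2 `CC(C)CCc1cnc(CCc2ccc(-c3ccccc3C(=O)O)cc2)[nH]1` gives 10 nM, and the step of a 1.4-fold higher number from compound 1 to compound 2 (0.14 log units; within the scatter) shows that these two cannot be told apart. Compound 3 `O=C(O)c1ccccc1-c1ccc(CCc2ncc(CC3CC3)[nH]2)cc1` gives 72 nM, the highest number of the three, and the steps of a 9.9-fold higher number from compound 1 to compound 3 (0.99 log units; beyond the scatter) and a 7.2-fold higher number from compound 2 to compound 3 (0.86 log units; beyond the scatter) show that the cyclopropyl group leaves the most room for improvement.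

Compound 4 `Cc1ccc(Cc2cnc(CCc3ccc(-c4ccccc4C(=O)O)cc3)[nH]2)cc1` carries a change of the same kind: 4-methylphenyl in place of cyclopropyl on a saturated chain carbon bound to an aromatic carbon. The two measured steps that bear on it both involve swapping the cyclopropyl group for a larger saturated group, and both moved the number down by a modest but clear amount. Going by the values given here, a 4-methylphenyl group is larger still, though aromatic rather than saturated, which no measured compound covers. Compound 4 is therefore expected to show a lower number in this assay, with an estimated step of a 6.0-fold lower number from compound 3 to compound 4 (0.78 log units; beyond the scatter). Compound 4 is estimated at 12 nM, within a range from 3 nM to 50 nM.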

Compound 4, half-maximal effective concentration: 162 nM
The estimate for compound 4 lay 14-fold (1.13 log units) below the measured number; the whole stated range lies below it.
By their numbers in this assay, from the lowest: compounds 1 and 2 (each within the scatter of the next); then compound 3; then compound 4.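

At this position, more heavy atoms do not by themselves bring the number down in this assay: cyclopropyl gave way to the larger 4-methylphenyl group, and the result was a 2.3-fold higher number from compound 3 to compound 4 (0.35 log units; beyond the scatter) rather than the drop seen with the larger saturated groups. The gaps to those saturated groups are wider, with a 16-fold higher number from compound 2 to compound 4 (1.21 log units; beyond the scatter) for isobutyl and a 22-fold higher number from compound 1 to compound 4 (1.35 log units; beyond the scatter) for cyclohexyl, so among these four compounds the 4-methylphenyl group gives the highest number. No available evidence explains why this aromatic group behaves differently from the saturated ones.

Going by these compounds alone, it remains open whether any aromatic ring raises the number here or only this 4-methylphenyl group, a question that plain phenyl or a methoxy-substituted phenyl could address. Also open, on these data alone, is how a longer chain or a cyclohexyl ring carrying an amine would compare with compound 1.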